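Exchanging Oxygen for Sulfur in a Fused Ring

The compounds below may be only part of what the source reports. "The series", "measured", "known", "first", "only" and "open" are said of these compounds alone.

Measured in an assay on cells for displacement of a labelled ligand from 5-hydroxytryptamine receptor 1B (Homo sapiens), read by scintillation counting, with a stated time of 90 min; a higher number here means a weaker inhibitor, a lower number a stronger inhibitor:
Compound 1, `Cc1ncc2nccn2c1-c1ccc(Oc2nccc3occc23)cc1C(F)(F)F`, gives 8800 nM.
Compound 2, `FC(F)(F)c1cc(Oc2nccc3occc23)ccc1-c1cccc2nccn12`, gives 9300 nM.

Compound 2 sits alongside compound 1 on these numbers: the difference is a 1.1-fold higher number from compound 1 to compound 2 (0.02 log units; within the scatter). Compound 3, `FC(F)(F)c1cc(Oc2nccc3ccsc23)ccc1-c1cccc2nccn12`, arises from compound 2 by a change at the linking oxygen: a group of 9 heavy atoms (7 carbon, 1 nitrogen, 1 sulfur; one five-membered aromatic ring with 1 hetero atom, one six-membered aromatic ring with 1 hetero atom) in place of a group of 9 heavy atoms (7 carbon, 1 nitrogen, 1 oxygen; one five-membered aromatic ring with 1 hetero atom, one six-membered aromatic ring with 1 hetero atom), on an oxygen on an aromatic ring. Among the compounds with values here, only one measured step exists, the one from compound 1 to compound 2, and it alters a different part of the molecule, the group on an aromatic carbon, not the ring attached to the oxygen. Within the data shown here, it was small, a 1.1-fold higher number from compound 1 to compound 2 (0.02 log units; within the scatter), so it offers no guide to an oxygen-for-sulfur exchange, and no other step touches this position. With nothing to point either way, the expected step in this assay is a 1.2-fold lower number from compound 2 to compound 3 (0.09 log units; within the scatter), a change not beyond the scatter. Compound 3 is therefore estimated at 7500 nM, with a range of 2500 nM to 22000 nM.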

Compound 3, inhibition constant: 9900 nM
For compound 3 the middle estimate is 1.3-fold (0.12 log units) below the measured one; the measured number falls inside the stated range.
By their numbers in this assay, from the lowest: compounds 1, 2 and 3 (each within the scatter of the next).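

Within the data shown here, the first measured change at this position, sulfur taking the place of oxygen in the fused group, gives a 1.1-fold higher number from compound 2 to compound 3 (0.03 log units; within the scatter) in this assay and so does not separate the two groups. Together with a 1.1-fold higher number from compound 1 to compound 2 (0.02 log units; within the scatter) at the group on an aromatic carbon, this makes two changes in different places that both stay within the scatter, so neither place has yet shifted the number measurably. Nothing measured here says why exchanging these two atoms makes so little difference.

On these data alone, whether the number would respond to a quite different group on that oxygen, such as a plain phenyl ring or a chain ending in an amine, stays open. So does whether sulfur and oxygen would stay interchangeable on the core of compound 1.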